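A ring swap at the limit of the assay

The compounds below may be only part of what the source reports. "The series", "measured", "known", "first", "only" and "open" are said of these compounds alone.

Among the compounds with values here, in a functional assay on SMMC-7721 cells (Homo sapiens) for antiproliferative activity, read by MTT assay, with a stated time of 72 h (a lower number here means a stronger inhibitor, a higher number a weaker inhibitor), compound 1 `C#CCSc1nc(Sc2nnnn2CCN(C)C)c(C#N)c(-c2ccc(Cl)cc2)n1` gives 7340 nM, the only exact number so far. Compound 2 `C#CCSc1nc(Sc2nc(C)c(C)s2)c(C#N)c(-c2cc(OC)c(OC)c(OC)c2)n1` reads > 20000 nM, which is a limit and not a number. Compound 3 `C#CCSc1nc(Sc2ccccn2)c(C#N)c(-c2cc(OC)c(OC)c(OC)c2)n1` reads > 20000 nM, which is also a limit. Compound 3 therefore sits at the limit of > 20000 nM in this assay, at which 2 of the 3 values shown sit.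

Compound 4 `C#CCSc1nc(Sc2nncs2)c(C#N)c(-c2cc(OC)c(OC)c(OC)c2)n1` differs from compound 3 by one change, 1,3,4-thiadiazol-2-yl in place of pyridin-2-yl on a sulfur. The closest measured change is also a ring swap on that sulfur, a step that the two limits leave unreadable from compound 2 to compound 3. It gives no size to carry over. Compound 1 differs from compound 3 in more than one place, so it offers no clean comparison. With no sign yet that a ring swap here restores activity, compound 4 is expected to remain close to the limit. The expected step, a number no higher from compound 3 to compound 4 (the limit leaves the size open), is only a rough estimate, and its direction is uncertain. Compound 4 is estimated at 20000 nM, with an expected range of 9000 nM to 40000 nM.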

Compound 4, half-maximal inhibitory concentration: 4660 nM
Compound 4: the middle estimate sits 4.3-fold (0.63 log units) above what was measured, outside the stated range (below it).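

In this assay, the group on this sulfur can clearly change the read-out: 1,3,4-thiadiazol-2-yl in place of pyridin-2-yl gives an at least 4.2-fold lower number from compound 3 to compound 4 (0.63 log units; beyond the scatter), and 1,3,4-thiadiazol-2-yl in place of 4,5-dimethyl-1,3-thiazol-2-yl gives an at least 4.2-fold lower number from compound 2 to compound 4 (0.63 log units; beyond the scatter). The earlier ring swap could not be read, whereas these two steps show a direction, though each starts from a limit and so gives only a smallest size. Among the compounds that share this core, compound 4 alone has an exact number, and the other two stay at a limit: the limit of > 20000 nM in this assay, at which 2 of the 4 values shown sit.

On these data alone, it remains open whether a methyl group or an amine added to the 1,3,4-thiadiazol-2-yl ring would move the number further. Also open, as far as these compounds go, is how a plain phenyl ring on this sulfur would compare with these heteroaromatic rings.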